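The compounds below may be only part of what the source reports. "The series", "measured", "known", "first", "only" and "open" are said of these compounds alone.

Compound 2 `Nc1ccccc1NC(=O)c1ccc(Cn2cnc3c(Nc4cccc(Cl)c4)nc(Cl)nc32)cc1` stands lowest of the two numbers measured in a functional assay on NCI-H460 cells (Homo sapiens) for antiproliferative activity, read by CCK-8 assay, with a stated time of 72 h, tested at 2 uM (a lower number here means a weaker effect, a higher number a stronger effect of the compound at the concentration tested), where compound 2 gives 10.3%. Compound 1 `Nc1ccccc1NC(=O)c1ccc(Cn2cnc3c(Nc4ccccc4)nc(Cl)nc32)cc1` gives 42.7% in this assay. Compound 3 `CN1CCN(c2nc(Cl)nc3c2ncn3Cc2ccc(C(=O)Nc3ccccc3N)cc2)CC1` differs from compound 2 by 4-methylpiperazin-1-yl in place of (3-chlorophenyl)amino on an aromatic carbon. Among the measured compounds shown here, the only step seen at this place, a number 32.4 percentage points lower from compound 1 to compound 2 (beyond the scatter), shows that the number moves strongly with the group sitting there. For the measured compounds named here, no measured step exchanges (3-chlorophenyl)amino for 4-methylpiperazin-1-yl, so the direction is uncertain. Compound 3 is expected to move by a number 14.7 percentage points higher from compound 2 to compound 3 (beyond the scatter). The estimate for compound 3 is 25%, between 5% and 55%.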

Compound 3, a percentage reported as inhibition, at one concentration (the size of the read-out at that concentration, not a potency): 13.5%
Compound 3: the middle estimate sits 11.5 percentage points above what was measured; the measured number falls inside the stated range.
By their numbers in this assay, from the lowest: compounds 2 and 3 (each within the scatter of the next); then compound 1.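

In this assay, a number 3.2 percentage points higher from compound 2 to compound 3 (within the scatter) means that (3-chlorophenyl)amino and 4-methylpiperazin-1-yl cannot be told apart at this place, although one brings an aromatic ring and the other a non-aromatic ring. With a number 29.2 percentage points lower from compound 1 to compound 3 (beyond the scatter), 4-methylpiperazin-1-yl also falls short of plain anilino, so among these three compounds only compound 1, with anilino, gives the higher number. Nothing available explains these differences. Still open, on these data alone, is whether a small amine such as dimethylamino would match anilino or the other two groups, and how anilino bearing a methoxy group would compare.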